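Methyl in place of methoxy on the five-membered ring

The source may hold more compounds than are shown below. What is called first, only, known or untested is meant among the compounds shown, and "the series" means these compounds.

For the measured compounds named here, compound 2 `CCOCCOC(=O)C(=O)Nc1nc(-c2cc(OC)no2)cs1` is the one member of the series with a number in a functional assay on the whole organism with Rattus norvegicus as the target (on this read-out higher numbers stand for an effect only at larger amounts of compound and lower numbers for an effect already at smaller amounts), where compound 2 gives 11 mg/kg. Compound 1 `CCOCCOC(=O)C(=O)Nc1nc(-c2cc(Br)no2)cs1` carries bromo where compound 2 carries methoxy. In this assay compound 1 gives only the limit > 30 mg/kg, not a number. Going by the values given here, the single measured step, an at least 2.7-fold lower number from compound 1 to compound 2 (0.43 log units; beyond the scatter), is therefore anchored on one side by that limit (the limit of > 30 mg/kg in this assay, at which 1 of the 2 values shown sits), so its full size is not known. Compound 3 `CCOCCOC(=O)C(=O)Nc1nc(-c2cc(C)no2)cs1` differs from compound 2 in one place: methyl in place of methoxy on an aromatic carbon. Among the compounds with values here, no measured step exchanges methoxy for methyl at this aromatic carbon; the nearest evidence is an at least 2.7-fold lower number from compound 1 to compound 2 (0.43 log units; beyond the scatter), which ran at least modestly lower in dose, but it says nothing direct about methyl at that position. A step within the scatter, or a modest rise in the dose, is expected, a 1.4-fold higher number from compound 2 to compound 3 (0.13 log units; within the scatter). Compound 3 is accordingly estimated at 15 mg/kg in this assay, with an expected range from 6 mg/kg to 40 mg/kg.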

Compound 3, dose for half-maximal effect: 1.3 mg/kg
Estimate against measurement, compound 3: 12-fold (1.06 log units) above, and the stated range ends above it.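

In this assay, for the compounds shown here, the change from 3-methoxy-1,2-oxazol-5-yl to 3-methyl-1,2-oxazol-5-yl gives an 8.5-fold lower number from compound 2 to compound 3 (0.93 log units; beyond the scatter), the first step at this position read between two actual numbers; it shows that the group on the aromatic carbon next to the ring nitrogen strongly moves the dose, although the exchange removes only one heavy atom and one hydrogen-bond acceptor. Methyl also stands well apart from bromo, with an at least 23-fold lower number from compound 1 to compound 3 (1.36 log units; beyond the scatter), so among the three groups shown at this carbon, methyl gives the lowest dose, with steps beyond the scatter to both others. Compound 1 gives only a limit, so the full size of that second step stays unknown: the limit of > 30 mg/kg in this assay, at which 1 of the 3 values shown sits.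

The compounds shown do not tell whether an ethyl, a hydrogen or an amine at this carbon would keep, extend or lose the low dose seen with methyl. They also leave open whether the same order of groups would hold with a carboxylic acid in place of the ester, since all three compounds share that ester chain.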